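The source may report more compounds than this note shows. Statements on the series, on what has been measured and on what is new or still open speak of the compounds shown alone.

Of the compounds shown here, three sharing one core have been measured in a functional assay on MDA-MB-231 cells (Homo sapiens) for inhibition, read by MTT assay, with a stated time of 72 h; on this read-out lower numbers stand for stronger inhibition and higher numbers for weaker inhibition. Compound 1 `O=C(CSc1nc(Nc2ccccc2)c2ccccc2n1)Nc1ccc([N+](=O)[O-])cc1` gives 16800 nM. Among the measured compounds shown here, compound 2 `CCc1ccc(NC(=O)CSc2nc(Nc3ccccc3)c3ccccc3n2)cc1` gives 33900 nM; the step between them, a 2.0-fold higher number from compound 1 to compound 2 (0.30 log units; within the scatter), is the only single-point change among the measured compounds. Compound 3 `C=CC(=O)Nc1cccc(NC(=O)CSc2nc(Nc3ccccc3Cl)c3ccccc3n2)c1` gives 12700 nM, the lowest of the three numbers, yet it sits within the scatter of compound 1 and differs from compound 2 by a gap that lies beyond it.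

Compound 4 `C=CC(=O)Nc1cccc(NC(=O)CSc2nc(Nc3ccc(CC)cc3)c3ccccc3n2)c1` has not yet been measured. It differs from compound 3 by one change: 4-ethylphenyl in place of 2-chlorophenyl on a nitrogen on an aromatic ring. For the measured compounds named here, no measured step swaps a 2-chlorophenyl for a 4-ethylphenyl on this nitrogen, so no step bears directly on it. Going by the values given here, the one measured step, from compound 1 to compound 2, places an ethyl in place of a nitro elsewhere and stays within the scatter, which suggests that an ethyl group on an aromatic ring does not by itself move this read-out much.

The estimate for compound 4 is therefore a step of a 1.3-fold higher number from compound 3 to compound 4 (0.10 log units; within the scatter) that stays within the scatter. Compound 4 is expected to give 16000 nM, with a range from 6000 nM to 45000 nM.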

Compound 4, half-maximal inhibitory concentration: 14400 nM
Estimate against measurement, compound 4: 1.1-fold (0.05 log units) above; the measured number falls inside the stated range.
By their numbers in this assay, from the lowest: compounds 3, 4, 1 and 2 (each within the scatter of the next, the first and the last beyond it).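

In this assay, placing 4-ethylphenyl in place of 2-chlorophenyl on the nitrogen gives a 1.1-fold higher number from compound 3 to compound 4 (0.05 log units; within the scatter). Among the compounds shown here, this is the first measured change at this position, and it shows that this aryl group can be exchanged for another without a step beyond the scatter. The result also extends the earlier hint from a different position: here too, a change involving an ethyl group leaves the number within the scatter, although nothing available explains this.

The chlorine and the ethyl group differ in one step, so their separate contributions cannot be told apart from these compounds. From the compounds shown here alone, it also remains open whether an amine or a carboxylic acid on this phenyl ring would move the number beyond the scatter.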